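This account rests on a few compounds, and the source may have more. Where it says the series, first, only, none or still open, it means among the compounds named here.

Working notes on the series. Compound 1 `COc1cnc(-c2cnccn2)c2[nH]cc(C(=O)C(=O)N3CCN(C(=O)c4ccccn4)[C@@H](C)C3)c12` and compound 2 `COc1cnc(-n2cnc(N3CCN(C)CC3)n2)c2[nH]cc(C(=O)C(=O)N3CCN(C(=O)c4ccccc4)CC3)c12` share a core and were both run in a functional assay on MT2 cells (Homo sapiens) for cytotoxicity, read by XTT assay, with a stated time of 3 days; a lower number here means that less compound is tolerated, a higher number that more compound is tolerated. For compound 1 the reading is a limit of the assay, >= 267000 nM. For compound 2 the reading is likewise a limit of the assay, > 300000 nM. Among the compounds with values here, compound 2 therefore stands at the limit of > 300000 nM in this assay, at which 1 of the 2 values shown sits, while the other value on record sits at the limit of >= 267000 nM in this assay, at which 1 of the 2 values shown sits; both are limits rather than numbers, so no step between them can be stated.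

Compound 3 `CCCS(=O)(=O)c1ncn(-c2ncc(OC)c3c(C(=O)C(=O)N4CCN(C(=O)c5ccccc5)CC4)c[nH]c23)n1` is not yet measured in this assay. The change from compound 2 is propylsulfonyl in place of 4-methylpiperazin-1-yl on an aromatic carbon. Within the data shown here, with compound 2 at > 300000 nM, this assay gives no measured step on which to build, and the expectation is no shift beyond the usual scatter, i.e. an at least 1.0-fold lower number from compound 2 to compound 3 (0.02 log units; that floor lies within the scatter). Compound 3 is accordingly estimated at 280000 nM, between 120000 nM and 300000 nM, most likely again reported as a limit.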

Compound 3, half-maximal cytotoxic concentration: 207000 nM
Beside the measured number, compound 3's estimate is 1.4-fold (0.13 log units) above it; the measured number falls inside the stated range.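

In this assay compound 3 is the only compound shown that gives a number rather than a limit, 207000 nM, so tolerance at this position now has a measured reading. Propylsulfonyl in place of 4-methylpiperazin-1-yl, on an aromatic carbon of a five-membered aromatic ring with 3 nitrogen, gives an at least 1.4-fold lower number from compound 2 to compound 3 (0.16 log units; that floor lies within the scatter). That step can be read only as a floor because compound 2 stands at a limit: the limit of > 300000 nM in this assay, at which 1 of the 3 values shown sits.

The compounds shown leave open how large the true step is and whether the reading follows the sulfonyl, the propyl chain or the loss of the piperazine ring. A plain propyl chain, a methylsulfonyl group or an open-chain amine such as dimethylamino on the same carbon would separate these parts in this assay.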